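The source may report more compounds than this note shows. Statements on the series, on what has been measured and on what is new or still open speak of the compounds shown alone.

Measured so far:
compound 1, `Cn1ccc2c(Oc3ccc(NC(=O)c4cc5cccnc5n(-c5ccc(F)cc5)c4=O)cc3)ccnc21`, in a functional assay on HT-29 cells (Homo sapiens) for antiproliferative activity, read by MTT assay, with a stated time of 72 h (a higher number here means a weaker inhibitor, a lower number a stronger inhibitor), compound 1 gives 250 nM.
compound 2, `Cn1ccc2c(Oc3ccc(NC(=O)c4cc5cccnc5n(-c5ccc(Br)cc5)c4=O)cc3)ccnc21`, in this assay compound 2 gives 690 nM.

Within the data shown here, these two compounds share a core and differ only in the halogen on the outer aromatic ring; the step of a 2.8-fold higher number from compound 1 to compound 2 (0.44 log units; beyond the scatter) is the single step known here. On the numbers shown, compound 2 stands as the higher of the two, and it is the starting point for the next change.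

Compound 3, `Cn1ccc2c(Oc3ccc(NC(=O)c4cc5cccnc5n(-c5ccc(Br)cc5)c4=O)cc3F)ccnc21`, is not yet measured. The change from compound 2 is fluoro in place of hydrogen on an aromatic carbon, and it sits on the central aromatic ring rather than on the outer ring where the halogen was exchanged.

Among the measured compounds shown here, no measured step bears on this change: the only known step concerns a different ring and a different kind of exchange, so it gives no guidance on adding a fluorine at this place. A small group entering at a position of this sort typically moves a number little, so compound 3 is expected to show no step beyond the scatter, a 1.2-fold lower number from compound 2 to compound 3 (0.06 log units; within the scatter), in this assay. Compound 3 is therefore estimated at 600 nM, with a range from 250 nM to 1500 nM.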

Compound 3, half-maximal inhibitory concentration: 330 nM
Compound 3: middle estimate off by 1.8-fold (0.26 log units), on the high side; measured number inside the range.
By their numbers in this assay, from the lowest: compounds 1 and 3 (each within the scatter of the next); then compound 2.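

Fluoro in place of hydrogen, on an aromatic carbon ortho to a large group and meta to a large group, is the first change shown at this place, and in this assay it gives a 2.1-fold lower number from compound 2 to compound 3 (0.32 log units; beyond the scatter). A single added fluorine atom, with no ring, no hydrogen-bond donor or acceptor and no net charge, is therefore enough to move the number beyond the usual scatter, so this position is not indifferent to substitution, though the step is modest. The earlier step, a 2.8-fold higher number from compound 1 to compound 2 (0.44 log units; beyond the scatter), came from exchanging one halogen for another elsewhere in the molecule, whereas this one lowers the number, and no available measurement explains why this happens.

The compounds shown leave open whether chloro, methyl, methoxy or an amine at this same place would lower the number further, leave it unchanged or raise it. They also leave open whether the same fluoro would give a step of similar size when the outer ring carries fluoro rather than bromo, since this single step was read with bromo in place.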